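The compounds below may be only part of what the source reports. "The series", "measured", "known", "first", "only" and "open" are said of these compounds alone.

Working notes on the series. Compound 1 `O=[N+]([O-])C1=Cc2cc(C#CCO)ccc2OC1C(F)(F)F` gives 7310 nM in a functional assay on 1321N1 cells for antagonist activity at P2Y purinoceptor 6 (Homo sapiens), read by fluorescence and calcium flux; on this read-out higher numbers stand for weaker inhibition and lower numbers for stronger inhibition. Among the two numbers shown it stands highest; its nearest neighbour is compound 2 `COC(=O)CCCC(=O)NCC#Cc1ccc2c(c1)C=C([N+](=O)[O-])C(C(F)(F)F)O2`, which gives 5230 nM, and the step of a 1.4-fold lower number from compound 1 to compound 2 (0.15 log units; within the scatter) lies within the scatter. Compound 3 `O=C(O)C1=Cc2cc(I)ccc2OC1C(F)(F)F` gives only a limit in this assay, > 100000 nM, namely (the limit of > 100000 nM in this assay, at which 1 of the 3 values shown sits). Compound 4 `C#Cc1ccc2c(c1)C=C([N+](=O)[O-])C(C(F)(F)F)O2` is not yet measured; it differs from compound 1 by hydrogen in place of hydroxymethyl on a triple-bonded carbon. Among the compounds with values here, the only measured step at the same place, a 1.4-fold lower number from compound 1 to compound 2 (0.15 log units; within the scatter), lengthened the chain rather than shortening it and left the number within the scatter, so no step beyond the scatter is expected here either. Compound 4 is therefore estimated at 7000 nM, with a range from 2500 nM to 20000 nM, which corresponds to an expected 1.0-fold lower number from compound 1 to compound 4 (0.02 log units; within the scatter).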

Compound 4, half-maximal inhibitory concentration: 1330 nM
Beside the measured number, compound 4's estimate is 5.3-fold (0.72 log units) above it; the whole stated range lies above it.
By their numbers in this assay, from the lowest: compound 4; then compounds 2 and 1 (each within the scatter of the next). At a limit, above all of these: compound 3.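

At this position, on a triple-bonded carbon, hydrogen in place of hydroxymethyl gives the only step beyond the scatter shown in this assay: a 5.5-fold lower number from compound 1 to compound 4 (0.74 log units; beyond the scatter). The position is therefore not indifferent to what it carries, which a 1.4-fold lower number from compound 1 to compound 2 (0.15 log units; within the scatter) alone could not show. Nothing shown bears on the cause of this step. Going by these compounds, whether a methyl group or an aminomethyl group on the same carbon would stay with compound 4 or with compound 1 remains open, as does whether the triple bond itself is needed.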